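The source may hold more compounds than are shown below. What is called first, only, known or untested is meant among the compounds shown, and "the series" means these compounds.

Three compounds have been measured in an ADME assay on HEL cells (Homo sapiens) for cytotoxicity; on this read-out higher numbers stand for lower toxicity in this test and lower numbers for higher toxicity in this test:

Compound 1, `COc1cc(/C=N/NC(=O)COc2cccc3ccccc23)cc(OC)c1OC`, gives 47.9 ug/mL.
Compound 2, `O=C(COc1cccc2ccccc12)N/N=C/c1ccc(O)cc1`, gives 60.6 ug/mL.
Compound 3, `CCOc1ccc(/C=N/NC(=O)COc2cccc3ccccc23)cc1O`, gives 18.1 ug/mL.

In this assay compound 2 holds the highest of the three numbers, but its nearest neighbour, compound 1, lies within the usual scatter of it, so the two cannot be told apart. Compound 3 is the only one that stands clearly apart, with a number well below that of compound 2. All three share the same core and differ only at one end of the molecule.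

Compound 4, `CSc1ccc(/C=N/NC(=O)COc2cccc3ccccc23)cc1`, has not yet been measured. Against compound 2 the change is methylsulfanyl in place of hydroxy on an aromatic carbon. For the measured compounds named here, no pair of measured compounds differs in just one place, so no measured step can guide this change directly. What the numbers do show is that changes at this end of the molecule have shifted the read-out beyond the scatter in one case, compound 3, and not in the other, compound 1. Going by the values given here, a modest step is expected in this assay from compound 2 to compound 4, more likely toward a lower number, because compound 3 gives 18.1 ug/mL and the one clear departure from compound 2 thus lies on the low side. The step from compound 2 to compound 4 is expected to be a 1.7-fold lower number from compound 2 to compound 4 (0.24 log units; within the scatter). Compound 4 is therefore estimated at 35 ug/mL, with a range from 12 ug/mL to 90 ug/mL.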

Compound 4, half-maximal cytotoxic concentration: > 100 ug/mL
Compound 4 gave a limit, no number; the forecaster's own chance of this, stated with the estimate: 10%; middle value at least 2.8-fold (0.45 log units) from the limit.
By their numbers in this assay, from the lowest: compound 3; then compounds 1 and 2 (each within the scatter of the next). At a limit, above all of these: compound 4.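

For the compounds shown here, this is the first step at this end of the molecule that can be read as a single change: in this assay, putting methylsulfanyl in place of hydroxy on an aromatic carbon gives an at least 1.6-fold higher number from compound 2 to compound 4 (0.21 log units; that floor lies within the scatter). The value of compound 4, > 100 ug/mL, is a limit of the assay and not a number. The change removes the hydrogen-bond donor of the hydroxy group without any drop in the read-out, but the floor of the step lies within the scatter, so a clear rise cannot be claimed from it, and only one value shown sits in this position: the limit of > 100 ug/mL in this assay, at which 1 of the 4 values shown sits.

On these data alone, it remains open whether the high reading goes with the arrival of methylsulfanyl or with the departure of hydroxy, and a methyl group, an amine or a chlorine atom on the same carbon would bear on that question. As far as these compounds go, the true size of the step also stays open, as does whether a longer sulfur-bearing chain, such as ethylsulfanyl, would read the same way.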